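This account rests on a few compounds, and the source may have more. Where it says the series, first, only, none or still open, it means among the compounds named here.

Measured so far:
- compound 1, `CC(=O)Nc1cc(NC(=O)Nc2cc(Cl)cc(Cl)c2)ccc1C`: 561 nM
- compound 2, `CC(=O)Nc1cc(NC(=O)Nc2ccc3c(c2)OCCO3)ccc1C`: > 30000 nM

In a functional assay on A375P cells (Homo sapiens) for antiproliferative activity (on this read-out lower numbers stand for stronger inhibition and higher numbers for weaker inhibition), compound 1 gives 561 nM. Compound 2 reaches only the limit of this assay, > 30000 nM, so it stands at the weak end of the numbers shown, as the limit of > 30000 nM in this assay, at which 1 of the 2 values shown sits, records. Among the compounds with values here, compound 3, `Cc1ccc(NC(=O)Nc2ccc3c(c2)OCCO3)cc1NC(=O)c1ccccc1`, carries phenyl in place of methyl on a carbonyl carbon; no measured step matches this change, so only a modest move toward stronger inhibition, or none beyond the scatter, is expected, as an at least 1.5-fold lower number from compound 2 to compound 3 (0.17 log units; that floor lies within the scatter). For compound 3 the estimate is 20000 nM, with a range from 5000 nM to 60000 nM, and a real chance that this assay again reports only a limit.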

Compound 3, half-maximal inhibitory concentration: > 30000 nM
Compound 3: no number, only a limit; the forecaster's own chance of this, stated with the estimate: 55%; at least 1.5-fold (0.17 log units) between middle value and limit.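

Compound 2 and compound 3 both sit at a limit in this assay, so no step can be read for phenyl in place of methyl on a carbonyl carbon: the limit of > 30000 nM in this assay, at which 2 of the 3 values shown sit.

As far as these compounds go, whether this change shifts activity at all, and in which direction, stays open.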